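Configuration-only steps in a small cytotoxicity series

The source may report more compounds than this note shows. Statements on the series, on what has been measured and on what is new or still open speak of the compounds shown alone.

Of the compounds shown here, two carry numbers so far. Compound 1 `CC(C)[C@H]1CC[C@H](C)C[C@@H]1O[C@@H]1O[C@H](CO[C@@H]2O[C@H](COC(=O)c3ccc(Br)cc3)[C@@H](OC(=O)c3ccc(Br)cc3)[C@H](O)[C@H]2O)[C@@H](O)[C@H](O)[C@H]1O` and compound 2 `CC(C)[C@@H]1CC[C@@H](C)C[C@H]1O[C@@H]1O[C@H](CO[C@@H]2O[C@H](COC(=O)c3ccc(Br)cc3)[C@@H](OC(=O)c3ccc(Br)cc3)[C@H](O)[C@H]2O)[C@@H](O)[C@H](O)[C@H]1O` share every atom and bond and differ only in how three stereocentres are drawn. In a functional assay on U-937 cells (Homo sapiens) for cytotoxicity, read by MTT assay, with a stated time of 72 h (a lower number here means a stronger inhibitor, a higher number a weaker inhibitor), compound 1 gives 14100 nM, and compound 2 gives 9200 nM. Within the data shown here, the single measured step is a 1.5-fold lower number from compound 1 to compound 2 (0.19 log units; within the scatter), and the only thing it can rest on is the fact that compounds 1 and 2 differ only in the configuration as drawn. Compound 2 holds the lowest of the two numbers, but its separation from compound 1 is within the scatter, so no order between them is claimed.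

Compound 3 `CC(C)[C@H]1CC[C@H](C)C[C@@H]1O[C@H]1O[C@H](CO[C@@H]2O[C@H](COC(=O)c3ccc(Br)cc3)[C@@H](OC(=O)c3ccc(Br)cc3)[C@H](O)[C@H]2O)[C@@H](O)[C@H](O)[C@H]1O` is not yet measured. Relative to compound 2 the change is again purely configurational: the two compounds have the same atoms and bonds and differ only in configuration as drawn: 4 of 13 stereo elements differ; a stereocentre at a saturated ring carbon is drawn S in compound 2 and R in compound 3; a stereocentre at a saturated ring carbon is drawn R in compound 2 and S in compound 3; a stereocentre at a saturated ring carbon is drawn R in compound 2 and S in compound 3; a stereocentre at a saturated ring carbon is drawn R in compound 2 and S in compound 3. Among the measured compounds shown here, the one step that bears on it, a 1.5-fold lower number from compound 1 to compound 2 (0.19 log units; within the scatter), was a configurational change that stayed within the scatter. For the measured compounds named here, compound 3 touches one more stereo element than that step did, and no measured pair speaks to that added element. The expected step is a 1.3-fold higher number from compound 2 to compound 3 (0.12 log units; within the scatter), no direction beyond the scatter. Compound 3 is therefore estimated at 12000 nM, within a range of 5000 nM to 30000 nM.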

Compound 3, half-maximal inhibitory concentration: 6900 nM
Estimate against measurement, compound 3: 1.7-fold (0.24 log units) above, and the stated range covers the measured number.
By their numbers in this assay, from the lowest: compounds 3, 2 and 1 (each within the scatter of the next, the first and the last beyond it).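

In this assay the series now holds a step beyond the scatter, a 2.0-fold lower number from compound 1 to compound 3 (0.31 log units; beyond the scatter), and it is modest, yet it comes from the smallest change among the three pairs, one stereocentre at a saturated ring carbon drawn R in compound 1 and S in compound 3. Nothing else separates that pair, so this single stereocentre is the only structural difference to which the step can be referred: the fact that compounds 1 and 3 differ only in the configuration as drawn. Among these compounds, the pair with the most changed stereo elements gives only a 1.3-fold lower number from compound 2 to compound 3 (0.12 log units; within the scatter), within the scatter, so across these three compounds the size of a step does not follow the number of stereo elements changed, and the only difference in that pair is again configurational: the fact that compounds 2 and 3 differ only in the configuration as drawn.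

As far as these compounds go, whether this stereocentre would give a step of similar size with an amine or a carboxylic acid in place of the ester groups on the shared core remains open. Also open is whether the modest step would hold in any other cell assay, and the compounds shown do not say how the configuration acts on the cells.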